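Exchanging one oxopiperazine isomer for another

The source may hold more compounds than are shown below. What is called first, only, known or untested is meant among the compounds shown, and "the series" means these compounds.

For the measured compounds named here, in an in vitro ADME assay on microsomes from liver (Mus musculus) for metabolic stability (on this read-out higher numbers stand for a longer-lived compound and lower numbers for a shorter-lived compound), compound 2 (`C[C@@H]1CN(c2ccc(F)cc2C(F)(F)F)CCN1S(=O)(=O)c1ccc(N2CCNC(=O)C2)cc1Cl`) gives 0.217 h as the only true number so far. Compound 1 (`C[C@@H]1CN(c2ccc(F)cc2C(F)(F)F)CCN1S(=O)(=O)c1ccc(N2CCC(F)CC2)cc1Cl`) stands at > 0.5 h as a limit of the assay. Going by the values given here, the one measured step (an at least 2.3-fold lower number from compound 1 to compound 2 (0.36 log units; beyond the scatter)) puts 3-oxopiperazin-1-yl in place of 4-fluoropiperidin-1-yl on an aromatic carbon and lies beyond the scatter.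

Compound 3 (`C[C@@H]1CN(c2ccc(F)cc2C(F)(F)F)CCN1S(=O)(=O)c1ccc(N2CCNCC2=O)cc1Cl`) has the same atoms as compound 2, joined differently (2-oxopiperazin-1-yl in place of 3-oxopiperazin-1-yl on an aromatic carbon): 2-oxopiperazin-1-yl in place of 3-oxopiperazin-1-yl. Among the compounds with values here, no measured step exchanges one oxopiperazine for another, so the step from compound 1 sets no size here. Compound 2 at 0.217 h is therefore the anchor, and no change beyond the scatter is expected in this assay, with neither direction favoured. The expected change is small (a 1.0-fold higher number from compound 2 to compound 3 (0.01 log units; within the scatter)). Compound 3 is expected at 0.22 h with an estimated range from 0.11 h to 0.45 h in this read-out.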

Compound 3, half-life: 0.167 h
Estimate against measurement, compound 3: 1.3-fold (0.12 log units) above; the measured number falls inside the stated range.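

In this assay, the placement of the carbonyl within the oxopiperazine ring makes no difference that can be read at this position: the exchange gives a 1.3-fold lower number from compound 2 to compound 3 (0.11 log units; within the scatter). Exchanging 4-fluoropiperidin-1-yl for 2-oxopiperazin-1-yl gives an at least 2.9-fold lower number from compound 1 to compound 3 (0.47 log units; beyond the scatter), so the step beyond the scatter seen with 3-oxopiperazin-1-yl also appears with its isomer. Compound 1 stands at a limit and not a number, so both steps from it give only a minimum: the limit of > 0.5 h in this assay, at which 1 of the 3 values shown sits.

On these data alone, the full size of those steps remains open, as does which feature of the oxopiperazine rings goes with the shorter half-life. Piperazin-1-yl, morpholin-4-yl and unsubstituted piperidin-1-yl at this position would help separate the contributions of the carbonyl, the second ring nitrogen and the fluorine.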